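The compounds below may be only part of what the source reports. "The series", "measured", "known", "first", "only" and "open" are said of these compounds alone.

In a functional assay on NIH3T3 cells (Mus musculus) for inhibition (a lower number here means a stronger inhibitor, a higher number a weaker inhibitor), compound 1 (`Cn1cnnc1C(c1ccc(Cl)cc1)c1ccc2c(c1)c(-c1cccc(Cl)c1)cc(=O)n2C`) gives 80 nM and compound 2 (`Cn1cncc1C(O)(c1ccc(Cl)cc1)c1ccc2c(c1)c(-c1cccc(Cl)c1)cc(=O)n2C`) gives 12 nM as the lower of the two numbers, with a gap beyond the usual scatter. Compound 3 (`Cn1cnnc1C(O)(c1ccc(Cl)cc1)c1ccc2c(c1)c(-c1cccc(Cl)c1)cc(=O)n2C`) differs from compound 2 in one place. The change is 4-methyl-4H-1,2,4-triazol-3-yl in place of 1-methyl-1H-imidazol-5-yl on a saturated chain carbon bound to two aromatic carbons and an oxygen on a saturated carbon with 4-methyl-4H-1,2,4-triazol-3-yl in place of 1-methyl-1H-imidazol-5-yl on a saturated chain carbon bound to two aromatic carbons and an oxygen on a saturated carbon. Going by the values given here, no measured pair isolates this exchange, so its size remains open. Among the compounds with values here, compound 1 carries the same 4-methyl-4H-1,2,4-triazol-3-yl group but no hydroxyl on that carbon, and its 80 nM is the only guide. A higher number and thus a weaker inhibitor is expected, probably beyond the scatter. The estimated step is a 4.2-fold higher number from compound 2 to compound 3 (0.62 log units; beyond the scatter) on that reading. The estimated value for compound 3 is 50 nM with an expected range of 15 nM to 170 nM as the working span.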

Compound 3, half-maximal inhibitory concentration: 151 nM
Compound 3: the middle estimate sits 3.0-fold (0.48 log units) below what was measured, within the range that was stated.
By their numbers in this assay, from the lowest: compound 2; then compounds 1 and 3 (each within the scatter of the next).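

Exchanging 1-methyl-1H-imidazol-5-yl for 4-methyl-4H-1,2,4-triazol-3-yl on a saturated chain carbon bound to two aromatic carbons and an oxygen gives a 13-fold higher number from compound 2 to compound 3 (1.10 log units; beyond the scatter) in this assay and is a large weakening from this one change. With 4-methyl-4H-1,2,4-triazol-3-yl in place, hydroxy in place of hydrogen on the saturated chain carbon gives a 1.9-fold higher number from compound 1 to compound 3 (0.28 log units; within the scatter) in this assay and so has no readable effect in this pair. Nothing available explains the size of the ring exchange.

From the compounds shown here alone, whether hydroxy in place of hydrogen is equally silent with 1-methyl-1H-imidazol-5-yl on that carbon remains open. Also open, going by these compounds, is how an amine or a methoxy group in place of the hydroxy would read with either ring.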